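The compounds below may be only part of what the source reports. "The series", "measured", "known", "first", "only" and "open" are said of these compounds alone.

Measured so far in an ADME assay on the whole organism (strain Balb/c) for metabolic stability, with Mus musculus as the target, read by LC-MS, at a dose of 3 mg/kg by the intravenous route (on this read-out higher numbers stand for a longer-lived compound and lower numbers for a shorter-lived compound), for the series
compound 1 `CC(Oc1ccc(F)c(C(N)=O)c1F)c1nc(-c2ccc(C(F)(F)F)cc2)c(Br)o1` gives 1.05 h
compound 2 `CCc1oc(COc2ccc(F)c(C(N)=O)c2F)nc1-c1ccc(OC)cc1` gives 0.167 h
compound 3 `CCCc1oc(COc2ccc(F)c(C(N)=O)c2F)nc1-c1ccc(Cl)cc1` gives 0.417 h

Compound 1 stands highest of the three. Compound 3 lies lower and compound 2 lowest, both beyond the scatter of compound 1.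

Compound 4 `CC(Oc1ccc(F)c(C(N)=O)c1F)c1nc(-c2ccc(OC(F)(F)F)cc2)c(Br)o1` is still to be measured. It keeps the core of compound 1 and carries trifluoromethoxy in place of trifluoromethyl on an aromatic carbon, para to a large group, with trifluoromethoxy in place of trifluoromethyl on an aromatic carbon as the counted difference.

Going by the values given here, no measured pair differs in one place only, so the data hold no direct guide to this change. Among the compounds with values here, the expectation therefore starts from compound 1 at 1.05 h as the only measured compound with the same core. In this assay no step beyond the scatter is expected, and the estimated change is a 1.2-fold lower number from compound 1 to compound 4 (0.07 log units; within the scatter) in size. Compound 4 is expected at 0.9 h within an estimated range of 0.45 h to 1.8 h for this measurement.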

Compound 4, half-life: 0.883 h
For compound 4 the middle estimate is 1.0-fold (0.01 log units) above the measured one; the measured number falls inside the stated range.
By their numbers in this assay, from the lowest: compound 2; then compound 3; then compounds 4 and 1 (each within the scatter of the next).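

In this assay the series now holds a step that changes one place only: trifluoromethoxy in place of trifluoromethyl on an aromatic carbon, para to a large group, gives a 1.2-fold lower number from compound 1 to compound 4 (0.08 log units; within the scatter), within the scatter. On the core of compound 1, this position therefore takes the extra oxygen, counted as one hydrogen-bond acceptor, without a change that this read-out can separate from the scatter. Nothing at hand gives a reason for this outcome.

On these data alone, whether a group of another kind at this position, such as a nitrile or an amine, would stay within the scatter remains open. Also open, as far as these compounds go, is whether the same exchange would give a similar step in a compound that keeps the rest of compound 2 or compound 3.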